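Swapping a Methyl Anchor for a Nitro Group

This account rests on a few compounds, and the source may have more. Where it says the series, first, only, none or still open, it means among the compounds named here.

Three compounds sharing one core were tested in a functional assay on SW480 cells (Homo sapiens) for cytotoxicity, read by MTT assay, with a stated time of 48 h; a lower number here means a stronger inhibitor, a higher number a weaker inhibitor. Compound 1 `O=c1ccoc2cc(OCc3cn(Cc4ccc(Cl)cc4)nn3)ccc12` gives > 100000 nM in this assay, which is a limit of the assay rather than a number. Compound 2 `Cc1ccccc1Cn1cc(COc2ccc3c(=O)ccoc3c2)nn1` likewise gives > 100000 nM, again only a limit. Compound 3 `O=c1ccoc2cc(OCc3cn(Cc4ccc(Br)cc4)nn3)ccc12` gives a number, 37500 nM. Compound 2 thus stands at the top edge of what was measured, sharing the limit of > 100000 nM in this assay, at which 2 of the 3 values shown sit, with compound 1, while only compound 3 sits below it.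

The measured steps are these. a step that the two limits leave unreadable from compound 1 to compound 2. an at least 2.6-fold lower number from compound 1 to compound 3 (0.42 log units; beyond the scatter). an at least 2.6-fold lower number from compound 2 to compound 3 (0.42 log units; beyond the scatter).

Compound 4 `O=c1ccoc2cc(OCc3cn(Cc4ccc([N+](=O)[O-])cc4)nn3)ccc12` has not yet been measured. It differs from compound 2 in one place: 4-nitrophenyl in place of 2-methylphenyl on a saturated chain carbon bound to an aromatic nitrogen. Among the compounds with values here, only the step from compound 2 to compound 3 bears directly on this change, as both replace the 2-methylphenyl, one with 4-bromophenyl, the other with 4-nitrophenyl, and that step was at least modest toward a lower number. Within the data shown here, no measured compound carries a nitro group. The expected step is an at least 2.0-fold lower number from compound 2 to compound 4 (0.30 log units; that floor lies within the scatter), a lowering of a size close to the measured one. Compound 4 is therefore estimated to give about 50000 nM, with a range from 15000 nM to 150000 nM.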

Compound 4, half-maximal inhibitory concentration: 19300 nM
The estimate for compound 4 lay 2.6-fold (0.41 log units) above the measured number, and the stated range covers the measured number.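

The nitro compound gives a second real number on the shared core in this assay, so a measurable value at this position no longer rests on the 4-bromophenyl compound alone: the result is an at least 5.1-fold lower number from compound 2 to compound 4 (0.71 log units; beyond the scatter), and also an at least 5.1-fold lower number from compound 1 to compound 4 (0.71 log units; beyond the scatter). Changing bromo to nitro on the aromatic carbon gives a 1.9-fold lower number from compound 3 to compound 4 (0.29 log units; within the scatter), so compound 3 and compound 4 cannot be ordered, even though the two groups share no atoms. The steps from compound 1 and compound 2 are floors and not true sizes, since both compounds sit at a limit of the assay, and they also go against any rule that a substituted phenyl alone gives a measurable value: the limit of > 100000 nM in this assay, at which 2 of the 4 values shown sit.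

The compounds shown leave open whether an amine or a carboxylic acid in place of the nitro on the aromatic carbon, or a longer chain in place of the saturated chain carbon bound to the aromatic nitrogen, would keep a measurable value. They also cannot tell what separates the bromo and nitro compounds from the chloro compound, as only compound 3 and compound 4 give numbers.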